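This account rests on a few compounds, and the source may have more. Where it says the series, first, only, none or still open, it means among the compounds named here.

Compound 1 `Cc1ccc(CNC(=O)c2nn(-c3ccc(F)cc3)c(OC[C@@H](O)C[C@@H](O)CC(=O)O)c2C(C)C)cc1`: 15 nM
Compound 2 `CC(C)c1c(C(=O)N(C)Cc2cccc(F)c2)nn(-c2ccc(F)cc2)c1OC[C@@H](O)C[C@@H](O)CC(=O)O`: 14 nM

Both were tested in an assay on microsomes from liver for inhibition of 3-hydroxy-3-methylglutaryl-coenzyme A reductase (Rattus norvegicus); on this read-out higher numbers stand for weaker inhibition and lower numbers for stronger inhibition. Compound 2 gives 14 nM, and this number and the value of compound 1 lie within the usual scatter of each other. Among the measured compounds shown here, the single measured step, a 1.1-fold lower number from compound 1 to compound 2 (0.03 log units; within the scatter), changed the group on the amide and still stayed within the scatter. Compound 3 `CC(C)c1c(C(=O)N(C)Cc2ccc(F)cc2)nn(-c2ccc(F)cc2)c1OC[C@@H](O)C[C@@H](O)CC(=O)O` differs from compound 2 only by 4-fluorophenyl in place of 3-fluorophenyl on a saturated chain carbon bound to an amide-type nitrogen, which moves one fluorine around the same ring. For the measured compounds named here, no measured step tests this exact move, so compound 3 is expected to stay close, with no change at the digits printed from compound 2 to compound 3 (within the scatter) not beyond the scatter. The estimate for compound 3 is 14 nM, ranging from 6 nM to 32 nM.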

Compound 3, half-maximal inhibitory concentration: 18 nM
For compound 3 the middle estimate is 1.3-fold (0.11 log units) below the measured one; low and high end bracket the measured number.
By their numbers in this assay, from the lowest: compounds 2, 1 and 3 (each within the scatter of the next).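

Moving the fluorine from 3-fluorophenyl to 4-fluorophenyl, on a saturated chain carbon bound to an amide-type nitrogen, gives a 1.3-fold higher number from compound 2 to compound 3 (0.11 log units; within the scatter) in this assay, so both fluorine placements sit within the scatter. Putting (4-fluorobenzyl)(methyl)amino in place of (4-methylbenzyl)amino on the carbonyl carbon gives a 1.2-fold higher number from compound 1 to compound 3 (0.08 log units; within the scatter), so this pair also stays within the scatter. No supporting measurement bears on why these numbers stay so close. Going by these compounds, it remains open whether the number would hold with a carboxylic acid or an amine in place of the fluorine.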